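The source may report more compounds than this note shows. Statements on the series, on what has been measured and on what is new or still open speak of the compounds shown alone.

Compound 1 `COc1cc(-c2ccnc3cc(-c4ccc(Cl)cc4)nn23)cc(OC)c1OC` carries a chloro group on the outer benzene ring, and compound 2 `CCOC(=O)c1ccc(-c2cc3nccc(-c4cc(OC)c(OC)c(OC)c4)n3n2)cc1` carries an ethoxycarbonyl group in the same place on the same shared core. In a functional assay on A549 cells (Homo sapiens) for inhibition, read by CCK-8 assay, with a stated time of 48 h (on this read-out higher numbers stand for weaker inhibition and lower numbers for stronger inhibition), compound 1 gives 3070 nM. Compound 2 gives > 10000 nM in this assay, and that value is a limit of the assay rather than a measured number (the limit of > 10000 nM in this assay, at which 1 of the 2 values shown sits). The change from chloro to ethoxycarbonyl therefore brought an at least 3.2-fold higher number from compound 1 to compound 2 (0.51 log units; beyond the scatter).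

Compound 3 `COc1cc(-c2ccnc3cc(-c4ccc(C(F)(F)F)cc4)nn23)cc(OC)c1OC` is the next member. Compared with compound 2 the difference is trifluoromethyl in place of ethoxycarbonyl on an aromatic carbon. Going by the values given here, the one measured step that bears on this change is the loss of potency seen when the ethoxycarbonyl entered; here that same group leaves again and a trifluoromethyl, a small group without hydrogen-bond acceptors like the chloro of compound 1, takes its place. The expectation is thus a recovery, with the estimated step being an at least 2.0-fold lower number from compound 2 to compound 3 (0.30 log units; that floor lies within the scatter). For compound 3 the estimate in this assay is 5000 nM, expected to lie between 1500 nM and 20000 nM.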

Compound 3, half-maximal inhibitory concentration: 2070 nM
Compound 3: the middle estimate sits 2.4-fold (0.38 log units) above what was measured; the measured number falls inside the stated range.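

Replacing ethoxycarbonyl with trifluoromethyl in this assay gives an at least 4.8-fold lower number from compound 2 to compound 3 (0.68 log units; beyond the scatter), so a second group, and not chloro alone, restores activity at this place on the outer benzene ring. The value of compound 2 is a limit and not a number, which makes this step a floor: the limit of > 10000 nM in this assay, at which 1 of the 3 values shown sits. Chloro and trifluoromethyl cannot be told apart at this place, with a 1.5-fold lower number from compound 1 to compound 3 (0.17 log units; within the scatter), so among the three compounds shown, ethoxycarbonyl alone stands apart, while compound 1 and compound 3 read alike.

Ethoxycarbonyl and trifluoromethyl differ at once in their heavy atoms, in the double bond outside aromatic rings and in their hydrogen-bond acceptors, and these compounds cannot show which of those differences matters for the read-out. Also open, going by these compounds, is how a carboxylic acid, an amine, a nitrile or a plain methyl group would read at this place, and whether any group there can bring the number well below those of compound 1 and compound 3.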